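A few compounds are considered here, and "the series" means these few. Any claim that something is new, unique, unknown or untested is made for them only; others in the source may bear on it.

Compound 3, with the structure `CCCCCc1cc2ccccc2nc1-c1cn(-c2ccc(F)cc2)nn1`, is the compound with the highest of the two numbers measured in a functional assay on U-937 cells (Homo sapiens) for cytotoxicity, read by MTT assay, with a stated time of 24 h; on this read-out lower numbers stand for stronger inhibition and higher numbers for weaker inhibition: compound 3 gives 67.5 ug/mL. Its nearest neighbour is compound 2, `CCCCCCCCCCn1cc(-c2nc3ccccc3cc2CC)nn1`, which in this assay gives 12.7 ug/mL. Compound 1, `CCCCCCCCCCn1cc(-c2nc3ccccc3cc2C)nn1`, is reported in this assay only as a limit, > 100 ug/mL, as shown by the limit of > 100 ug/mL in this assay, at which 1 of the 3 values shown sits.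

Compound 4, `CCCCCCCCCCn1cc(-c2nc3ccccc3cc2CCCCC)nn1`, differs from compound 3 in one place: decyl in place of 4-fluorophenyl on an aromatic nitrogen. Within the data shown here, none of the measured steps concerns this position. Among the measured compounds shown here, the only measured step, an at least 7.8-fold lower number from compound 1 to compound 2 (0.89 log units; beyond the scatter), concerns a chain on the core, and compounds 1 and 2 both already carry the decyl group on the aromatic nitrogen, spanning a limit and a moderate number. For the measured compounds named here, the change from compound 3 to compound 4 therefore has no direct precedent, and its size is uncertain in both directions.

Drawing on the values of compound 2 in this assay, compound 4 is expected to give a number close to that of compound 2, estimated at 25 ug/mL (range 8 ug/mL to 80 ug/mL), meaning an expected step of a 2.7-fold lower number from compound 3 to compound 4 (0.43 log units; beyond the scatter).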

Compound 4, half-maximal inhibitory concentration: 18.2 ug/mL
Compound 4: the middle estimate sits 1.4-fold (0.14 log units) above what was measured; the range from low to high includes it.
By their numbers in this assay, from the lowest: compounds 2 and 4 (each within the scatter of the next); then compound 3. At a limit, above all of these: compound 1.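

In this assay, among these compounds, the change at the aromatic nitrogen, decyl in place of 4-fluorophenyl, gives a 3.7-fold lower number from compound 3 to compound 4 (0.57 log units; beyond the scatter), showing for the first time that the group at this position moves the number while the chain on the core stays the same. With decyl held in place, extending the chain on the core gives a 1.4-fold higher number from compound 2 to compound 4 (0.16 log units; within the scatter), whereas an at least 5.4-fold lower number from compound 1 to compound 4 (0.73 log units; beyond the scatter) lies beyond the scatter, so the marked difference among these decyl compounds separates compound 1 from the other two. That wider comparison starts from a value for compound 1 that is only a limit: the limit of > 100 ug/mL in this assay, at which 1 of the 4 values shown sits.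

The compounds shown leave open whether a shorter chain such as hexyl, or a phenyl without fluorine, on the aromatic nitrogen would fall nearer compound 3 or compound 4. They also leave open whether a longer chain on the core would keep the number of compound 4.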